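Three analogues measured, one trimethoxyphenyl variant awaited

The source may report more compounds than this note shows. Statements on the series, on what has been measured and on what is new or still open speak of the compounds shown alone.

Measured so far:
- Compound 1, `COc1cc(/C=C/C(=O)c2cccc(-n3cc(-c4ccc(Cl)cc4)[nH]c3=O)c2)ccc1O`: 2520 nM
- Compound 2, `COc1ccc(-c2cn(-c3cccc(C(=O)/C=C/c4cc(OC)c(OC)c(OC)c4)c3)c(=O)[nH]2)cc1`: 2590 nM
- Compound 3, `COc1ccc(-c2cn(-c3cccc(C(=O)/C=C/c4ccc(O)c(OC)c4)c3)c(=O)[nH]2)cc1`: 4570 nM

In a functional assay on BT-549 cells (Homo sapiens) for inhibition (on this read-out higher numbers stand for weaker inhibition of growth and lower numbers for stronger inhibition of growth), compound 2 stands second highest of the three, though all three lie within the scatter of one another. Compound 4, `COc1cc(/C=C/C(=O)c2cccc(-n3cc(-c4cc(OC)c(OC)c(OC)c4)[nH]c3=O)c2)cc(OC)c1OC`, differs from compound 2 by 3,4,5-trimethoxyphenyl in place of 4-methoxyphenyl on an aromatic carbon. For the measured compounds named here, no measured step makes this exact change. The nearest guide is a 1.8-fold higher number from compound 1 to compound 3 (0.26 log units; within the scatter), a change at the same aromatic carbon that stayed within the scatter; likewise a 1.8-fold higher number from compound 2 to compound 3 (0.25 log units; within the scatter), a swap of aryl groups elsewhere, stayed within the scatter. A step of similar modest size is therefore expected, a 1.0-fold higher number from compound 2 to compound 4 (0.00 log units; within the scatter), with no clear direction. Compound 4 is estimated at 2600 nM, between 1200 nM and 5600 nM.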

Compound 4, concentration for 50% growth inhibition: 1520 nM
Estimate against measurement, compound 4: 1.7-fold (0.23 log units) above; low and high end bracket the measured number.
By their numbers in this assay, from the lowest: compounds 4, 1, 2 and 3 (each within the scatter of the next, the first and the last beyond it).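

In this assay, placing 3,4,5-trimethoxyphenyl instead of 4-methoxyphenyl on this aromatic carbon of the five-membered ring gives a 1.7-fold lower number from compound 2 to compound 4 (0.23 log units; within the scatter). Unlike the chloro to methoxy step, this change replaces the whole aryl group, and even this larger group leaves the number within the scatter. Nothing measured here offers an explanation for this result. Going by these compounds, it remains open whether an amine or a carboxylic acid on this aryl ring, or a pyridine ring in its place, would move the number beyond the scatter.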